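Aryl amine swap on a shared tricyclic core

This account rests on a few compounds, and the source may have more. Where it says the series, first, only, none or still open, it means among the compounds named here.

Measured so far:
- Compound 1 `Cc1ccc(NC2=CC(=O)c3nc4n(c3C2=O)[C@H]2OC[C@@H](O)[C@H]2OC4)cc1`: 1420 nM
- Compound 2 `CCCc1ccc(NC2=CC(=O)c3c(nc4n3[C@H]3OC[C@@H](O)[C@H]3OC4)C2=O)cc1`: 1920 nM
- Compound 3 `Cc1ccc(NC2=CC(=O)c3c(nc4n3[C@H]3OC[C@@H](O)[C@H]3OC4)C2=O)cc1C`: 1050 nM

All three share one core and differ only in the aryl group on the amine nitrogen. In a functional assay on MGC-803 cells (Homo sapiens) for inhibition, read by sulforhodamine B assay (on this read-out lower numbers stand for stronger inhibition and higher numbers for weaker inhibition), compound 3 gives the lowest of the three numbers, yet its gaps to compound 1 and compound 2 both lie within the scatter, so no order among them can be claimed. Going by the values given here, the one recorded step, a 1.8-fold lower number from compound 2 to compound 3 (0.26 log units; within the scatter), is likewise within the scatter.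

Compound 4 `COc1ccccc1NC1=CC(=O)c2c(nc3n2[C@H]2OC[C@@H](O)[C@H]2OC3)C1=O` carries the change (2-methoxyphenyl in place of 3,4-dimethylphenyl on an amine nitrogen). Among the compounds with values here, no measured step touches a 2-methoxyphenyl group, and the only aryl swap seen moved nothing beyond noise, so a step of about a 1.4-fold higher number from compound 3 to compound 4 (0.15 log units; within the scatter) is expected, meaning none beyond the scatter. Compound 4 is therefore estimated at 1500 nM, between 600 nM and 3800 nM.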

Compound 4, half-maximal inhibitory concentration: 1670 nM
Compound 4: the middle estimate sits 1.1-fold (0.05 log units) below what was measured; the range from low to high includes it.
By their numbers in this assay, from the lowest: compounds 3, 1, 4 and 2 (each within the scatter of the next).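

In this assay the 2-methoxyphenyl group brings an oxygen and a hydrogen-bond acceptor that 3,4-dimethylphenyl does not have, yet the result is a 1.6-fold higher number from compound 3 to compound 4 (0.20 log units; within the scatter) and, against the 4-propylphenyl group, a 1.1-fold lower number from compound 2 to compound 4 (0.06 log units; within the scatter) and both steps stay within the scatter. This position on the amine nitrogen has therefore now taken a methoxy-bearing aryl group with no readable shift in the number. No measured evidence here offers an explanation for this result.

The compounds shown leave open whether a carboxylic acid or an amine on the phenyl ring would move the number beyond the scatter. They also leave open what a pyridine ring in place of the phenyl ring would do.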